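The compounds below may be only part of what the source reports. "The series", "measured", "known", "first", "only" and "open" are said of these compounds alone.

Working notes on the series. In an ADME assay on HeLa cells (Homo sapiens) for cytotoxicity, read by ATP content, with a stated time of 3 days (on this read-out lower numbers stand for higher toxicity in this test and higher numbers for lower toxicity in this test), compound 1 `COc1ccc(-n2c(=O)n(Cc3cc4cc(Cl)ccc4n3CCCC#N)c3cnccc32)c(C)c1` gives only a limit of the assay, > 50000 nM. Compound 2 `CC(C)CCn1c(Cn2c(=O)n(C3CC3)c3ccncc32)nc2cnccc21` likewise reaches only a limit, > 100000 nM. Compound 3 `O=c1n(Cc2nc3nc(Cl)ccc3n2CCCCF)c2cnccc2n1C1CC1` also stops at a limit, > 50000 nM. Compound 1 therefore stands among values that are all limits rather than numbers: the limit of > 50000 nM in this assay, at which 2 of the 3 values shown sit, and (the limit of > 100000 nM in this assay, at which 1 of the 3 values shown sits). Going by the values given here, on these figures no compound can be set apart from another, and no step between measured compounds is available in this assay.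

Compound 4 `COc1ccc(-n2c(=O)n(Cc3cc4cc(Cl)ccc4n3CCCC#N)c3cnccc32)cc1` has not been measured. It differs from compound 1 by hydrogen in place of methyl on an aromatic carbon. Among the compounds with values here, the change has no measured precedent within the three compounds at hand. The expected step that the limit leaves unreadable from compound 1 to compound 4 is none beyond the scatter. The expectation rests on compound 1, whose value is only a limit, > 50000 nM. Compound 4 is accordingly estimated at 60000 nM, within a range of 30000 nM to 200000 nM, most likely again reported as a limit.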

Compound 4, half-maximal cytotoxic concentration: > 50000 nM
Compound 4: a limit, no number (the forecaster's own chance of this, stated with the estimate: 85%); the middle value lies beyond the limit too.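

In this assay compound 4 gives > 50000 nM, a limit of the assay and not a number. Going by these compounds alone, compound 1 also stands at a limit, so no step from compound 1 to compound 4 can be read. The compounds shown leave open whether hydrogen in place of methyl on an aromatic carbon changes the cytotoxic concentration at all.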